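Diethylamino for dimethylamino on two related cores

A few compounds are considered here, and "the series" means these few. Any claim that something is new, unique, unknown or untested is made for them only; others in the source may bear on it.

Measured so far:
compound 1, `CN(C)CCCCn1c(N)c(-c2nc3ccccc3o2)c2nc(C#N)c(C#N)nc21`, 1380 nM in a functional assay on K562 cells (Homo sapiens) for antiproliferative activity, read by MTT assay, with a stated time of 48 h; a higher number here means a weaker inhibitor, a lower number a stronger inhibitor
compound 2, `CCN(CC)CCCCn1c(N)c(-c2nc3ccccc3o2)c2nc(C#N)c(C#N)nc21`, 1980 nM in this assay
compound 3, `CN(C)CCCCn1c(-c2c(N)n(C)c3nc(C#N)c(C#N)nc23)nc2ccccc21`, 11300 nM in this assay

Compounds 1 and 2 share one core and differ only in the amine at the chain end: diethylamino in place of dimethylamino on a saturated chain carbon, four bonds along the chain from an aromatic nitrogen. This change gave a 1.4-fold higher number from compound 1 to compound 2 (0.16 log units; within the scatter), so in this assay compound 1 and compound 2 cannot be told apart.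

Compound 3 carries a different core; the difference between the two cores is not broken down here. In this assay compound 3 stands at the highest of the three numbers, and its distance from compound 2 and from compound 1 lies beyond the scatter.

Compound 4, `CCN(CC)CCCCn1c(-c2c(N)n(C)c3nc(C#N)c(C#N)nc23)nc2ccccc21`, is not yet measured. It is related to compound 3 by the same kind of change that leads from compound 1 to compound 2: diethylamino in place of dimethylamino on a saturated chain carbon, four bonds along the chain from an aromatic nitrogen. Both changes sit at the same place, on a saturated chain carbon, four bonds along the chain from an aromatic nitrogen.

Since the earlier step was a 1.4-fold higher number from compound 1 to compound 2 (0.16 log units; within the scatter), compound 4 is expected to sit close to compound 3, with an estimated step of a 1.3-fold higher number from compound 3 to compound 4 (0.12 log units; within the scatter). The estimate for compound 4 in this assay is 15000 nM, between 7000 nM and 35000 nM. This expectation rests on a single observed pair on a different core, so it is held loosely.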

Compound 4, half-maximal inhibitory concentration: 3180 nM
Compound 4: the middle estimate sits 4.7-fold (0.67 log units) above what was measured; the whole stated range lies above it.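

In this assay, diethylamino in place of dimethylamino gave a 3.6-fold lower number from compound 3 to compound 4 (0.55 log units; beyond the scatter), while on the other core the same change gave a 1.4-fold higher number from compound 1 to compound 2 (0.16 log units; within the scatter). Set side by side, the two steps do not agree, so in this series the result of this change on one core could not be carried over to the other: the same change on two cores in this assay, a 1.4-fold higher number (0.16 log units; within the scatter) from compound 1 to compound 2 and a 3.6-fold lower number (0.55 log units; beyond the scatter) from compound 3 to compound 4, 5.1-fold (0.71 log units) apart, beyond the scatter of two such steps. For the compounds shown here, this shows that the effect of the change depends on the core it sits on, but with only one pair on each core it gives neither an explanation for the difference nor a rule for any further core.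

The compounds shown leave open whether a larger amine at the chain end, such as dipropylamino, would extend the step seen on the core of compound 3, and whether a primary amine would behave differently on the two cores. They also leave open whether the disagreement between the cores would persist with a shorter or longer chain carrying the same two amines.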